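The compounds below may be only part of what the source reports. "The series", "measured", "known", "first", "only" and "open" are said of these compounds alone.

Measured in a functional assay on CLL cells (Homo sapiens) for cytotoxicity, read by MTT assay, with a stated time of 48 h; on this read-out higher numbers stand for an effect only at larger amounts of compound and lower numbers for an effect already at smaller amounts:
- compound 1 `C=C(CC)C(=O)c1ccc(OCC(=O)Nc2ccc(C(=O)O)c(O)c2)c(Cl)c1Cl`: > 25000 nM (a limit of the assay)
- compound 2 `C=C(CC)C(=O)c1ccc(OCC(=O)Nc2ccc(O)c([N+](=O)[O-])c2)c(Cl)c1Cl`: 7400 nM
- compound 3 `C=C(CC)C(=O)c1ccc(OCC(=O)Nc2cccc(C(=O)O)c2)c(Cl)c1Cl`: 20600 nM

The result for compound 1 is a limit and not a number. That leaves two actual numbers in this assay. Compound 3 stands highest of these at 20600 nM, and compound 2 lies lower at 7400 nM, a gap beyond the usual scatter.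

The next compound is compound 4 `C=C(CC)C(=O)c1ccc(OCC(=O)Nc2ccc(C(C)=O)cc2)c(Cl)c1Cl`, in which 4-acetylphenyl replaces the 3-carboxyphenyl of compound 3 on an amide-type nitrogen: 4-acetylphenyl in place of 3-carboxyphenyl on an amide-type nitrogen. Among the compounds with values here, no measured pair of compounds differs in one place only, so the size of this step has to be judged indirectly. The closest guide is compound 2, which has no carboxyl group and gives 7400 nM. A moderate move to a lower number is therefore expected, probably just beyond the scatter, with the estimated step being a 2.9-fold lower number from compound 3 to compound 4 (0.47 log units; beyond the scatter). For compound 4 the estimated value is 7000 nM. The expected range for compound 4 runs from 2500 nM to 20000 nM.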

Compound 4, half-maximal effective concentration: 3900 nM
Beside the measured number, compound 4's estimate is 1.8-fold (0.25 log units) above it, and the stated range covers the measured number.
By their numbers in this assay, from the lowest: compounds 4 and 2 (each within the scatter of the next); then compound 3. At a limit, above all of these: compound 1.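

In this assay, within the data shown here, 4-acetylphenyl in place of 3-carboxyphenyl on an amide-type nitrogen gives a 5.3-fold lower number from compound 3 to compound 4 (0.72 log units; beyond the scatter), the first single change at this place that can be read on its own. The group at this place therefore matters to the read-out, even though the heavy-atom count and the six-membered aromatic ring stay the same, while the hydrogen-bond donor of the leaving group is gone and a carbon takes the place of an oxygen. Nothing measured here accounts for the size of this step.

The step changes both the group and its printed position number, so it cannot show which of the two counts. As far as these compounds go, a 4-carboxyphenyl or 3-acetylphenyl group would separate them, and an amine or a longer chain in place of the acetyl group remains open as well.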